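Cytotoxicity notes on a shared-core amide series

This account rests on a few compounds, and the source may have more. Where it says the series, first, only, none or still open, it means among the compounds named here.

Values in an ADME assay on MT4 cells (Homo sapiens) for cytotoxicity, read by MTT assay; a higher number here means that more compound is tolerated, a lower number that less compound is tolerated:
Compound 1 `Cc1cc(C)cc(S(=O)(=O)c2c(C(=O)NCC(=O)NCc3ccco3)[nH]c3ccc(Cl)cc23)c1` gives > 50000 nM, a limit of the assay.
Compound 2 `Cc1cc(C)cc(S(=O)(=O)c2c(C(=O)NC(C)C(=O)NCc3ccncc3)[nH]c3ccc(Cl)cc23)c1` gives 19500 nM.
Compound 3 `Cc1cc(C)cc(S(=O)(=O)c2c(C(=O)NC(C)c3ccco3)[nH]c3ccc(Cl)cc23)c1` gives > 54700 nM, a limit of the assay.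

Compound 3 therefore stands only at a limit, and one further value shown is a limit too the limit of > 54700 nM in this assay, at which 1 of the 3 values shown sits (the limit of > 50000 nM in this assay, at which 1 of the 3 values shown sits). Among the compounds with values here, the only numbered step reaching compound 3 is an at least 2.8-fold higher number from compound 2 to compound 3 (0.44 log units; beyond the scatter); the other, a step that the two limits leave unreadable from compound 1 to compound 3, is unreadable. Compound 4 `Cc1cc(C)cc(S(=O)(=O)c2c(C(=O)NC(C)c3cc(F)cc(F)c3)[nH]c3ccc(Cl)cc23)c1` carries the change (3,5-difluorophenyl in place of furan-2-yl on a saturated chain carbon bound to an amide-type nitrogen and a saturated chain carbon). Within the data shown here, no measured step touches this change, so no direction beyond the scatter is expected; the step of an at least 1.0-fold lower number from compound 3 to compound 4 (0.03 log units; that floor lies within the scatter) is the estimate. Compound 4 is expected at 50000 nM, within 20000 nM to 100000 nM, most likely again reported as a limit.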

Compound 4, half-maximal cytotoxic concentration: > 49700 nM
Compound 4 was reported as a limit; the forecaster's own chance of this, stated with the estimate: 60%; the middle value lies beyond the limit too.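

In this assay, the saturated chain carbon bound to the amide-type nitrogen now carries a six-membered aromatic ring of carbon only, and 3,5-difluorophenyl in place of ((pyridin-4-yl)methyl)carbamoyl gives an at least 2.5-fold higher number from compound 2 to compound 4 (0.40 log units; beyond the scatter). Compound 4 stands only at a limit of the assay: the limit of > 49700 nM in this assay, at which 1 of the 4 values shown sits. The steps to compound 4 from compound 1 and from compound 3 cannot be read, as both ends of each are limits.

So 3,5-difluorophenyl and furan-2-yl cannot be ordered here. Going by these compounds, whether an aminomethyl or a carboxylic acid at this carbon would give a number inside the assay's range stays open.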